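Methoxy removal on the shared core: working notes

A few compounds are considered here, and "the series" means these few. Any claim that something is new, unique, unknown or untested is made for them only; others in the source may bear on it.

Compound 3 `COc1ccc(-c2cn(-c3ccc(OC)c(OC)c3)nn2)cc1O` carries the methoxy that is removed. In a functional assay on MDA-MB-231 cells (Homo sapiens) for cytotoxicity, read by MTT assay (on this read-out lower numbers stand for stronger inhibition and higher numbers for weaker inhibition), compound 3 gives > 100 nM, which is a limit of the assay and not a number. Compound 1 `COc1ccc(-n2cc(-c3ccc(OC)c(O)c3)nn2)cc1` is the product of that removal: hydrogen in place of methoxy on an aromatic carbon. In this assay compound 1 gives > 10000 nM, again only a limit. The step that the two limits leave unreadable from compound 3 to compound 1 cannot be sized because the limit of > 100 nM in this assay, at which 1 of the 3 values shown sits, and the limit of > 10000 nM in this assay, at which 1 of the 3 values shown sits, bound both ends. Compound 2 `COc1ccc(-c2cn(-c3ccc(OC(F)(F)F)cc3)nn2)cc1OC` has a core whose difference from compound 3 is not broken down here. In this assay compound 2 gives > 1000 nM, also a limit, as the limit of > 1000 nM in this assay, at which 1 of the 3 values shown sits, states. Compound 4 `COc1ccc(-c2cn(-c3ccc(OC(F)(F)F)cc3)nn2)cc1` arises from compound 2 by the same change, (hydrogen in place of methoxy on an aromatic carbon), at the same place. Compound 4 is expected near 5000 nM, between 1000 nM and 30000 nM, meaning an estimated step that the limit leaves unreadable from compound 2 to compound 4. That expectation rests on the limit of compound 2 and on the unreadable step that the two limits leave unreadable from compound 3 to compound 1.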

Compound 4, half-maximal inhibitory concentration: 1000 nM
Estimate against measurement, compound 4: 5.0-fold (0.70 log units) above, within the range that was stated.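

On the core of compound 2, methoxy replaced by hydrogen gives a number no higher from compound 2 to compound 4 (the limit leaves the size open) in this assay. The same change on the core of compound 3 gives a step that the two limits leave unreadable from compound 3 to compound 1, and neither step can be read as a size, since each pair has at least one end that is a limit of the assay and not a number. The two pairs therefore show the same change made on two cores, but not whether it carries over from one core to the other with the same size or direction.

As far as these compounds go, it remains open how an amine or a carboxylic acid in place of that methoxy would read in this assay. From the compounds shown here alone, a longer chain at the same place is equally open.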